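Bromo in Place of Nitro: Expected Cytotoxicity of Compound 3

A few compounds are considered here, and "the series" means these few. Any claim that something is new, unique, unknown or untested is made for them only; others in the source may bear on it.

Two compounds have so far been measured in a functional assay on HepG2 cells (Homo sapiens) for cytotoxicity, read by sulforhodamine B assay, with a stated time of 48 h; a higher number here means a weaker inhibitor, a lower number a stronger inhibitor:

- compound 1, `C/C(=N/NC(=O)C(C#N)C(=S)S)c1ccc(NS(=O)(=O)c2ccc(C)cc2)cc1`, gives 11000 nM
- compound 2, `Cc1ccc(S(=O)(=O)Nc2ccc(C(=O)/C=C/c3ccc([N+](=O)[O-])cc3)cc2)cc1`, gives 26000 nM

Compound 2 stands at the highest of the two numbers, which means it is the weaker of the pair at holding back cell growth. Its nearest neighbour is compound 1, whose number is lower by a gap that lies beyond the usual scatter. For the measured compounds named here, the two compounds differ in more than one place, so no single step links them and only their two values can be set side by side.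

Compound 3, `Cc1ccc(S(=O)(=O)Nc2ccc(C(=O)/C=C/c3ccc(Br)cc3)cc2)cc1`, is a close relative of compound 2. Going by the values given here, the only change is bromo in place of nitro on an aromatic carbon.

Among the compounds with values here, no measured pair shows the effect of this change, so there is nothing to lean on beyond the two values given. The step from compound 2 to compound 3 is therefore expected to be small: a 1.3-fold lower number from compound 2 to compound 3 (0.11 log units; within the scatter), most likely within the scatter, with no clear direction. Compound 3 is estimated at 20000 nM, within a range from 7000 nM to 60000 nM.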

Compound 3, half-maximal inhibitory concentration: 30300 nM
Estimate against measurement, compound 3: 1.5-fold (0.18 log units) below; measured number inside the range.
By their numbers in this assay, from the lowest: compound 1; then compounds 2 and 3 (each within the scatter of the next).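

For the compounds shown here, this is the first measured step at this position: in this assay, going from 4-nitrophenyl to 4-bromophenyl gives a 1.2-fold higher number from compound 2 to compound 3 (0.07 log units; within the scatter), so this pair cannot be told apart. On this aromatic carbon, para to a large group, a single bromine atom can stand in for the three heavy atoms of nitro and its two hydrogen-bond acceptors with no change in the reading beyond the scatter, which shows that these two groups are interchangeable in this assay on this core. No independent measurement is available to explain why the two groups read alike.

The compounds shown leave open whether this position responds to any change at all, as only two groups have been compared there: an amine, a carboxylic acid or a plain hydrogen in the same place might read alike or might shift the number beyond the scatter. Whether bromo and nitro would also read alike on another core remains unsettled, as this is the only such pair shown.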